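This account rests on a few compounds, and the source may have more. Where it says the series, first, only, none or still open, it means among the compounds named here.

Compound 2 `COc1ccc(NC(=O)CCC(=O)OCCCCCCSc2ccc([N+](=O)[O-])c3nonc23)cc1` gives 8170 nM in an ADME assay on L02 cells (Homo sapiens) for cytotoxicity, read by MTT assay, with a stated time of 72 h; a higher number here means a weaker inhibitor, a lower number a stronger inhibitor; compound 1 `Cc1ccccc1NC(=O)CCC(=O)OCCCCCCSc1ccc([N+](=O)[O-])c2nonc12` gives 9490 nM, and the step of a 1.2-fold lower number from compound 1 to compound 2 (0.07 log units; within the scatter) lies within the scatter, so the two numbers cannot be told apart. Compound 3 `COc1ccc(NC(=O)CCC(=O)OCCCCCCSc2ccc([N+](=O)[O-])c3nonc23)cc1OC` differs from compound 2 by methoxy in place of hydrogen on an aromatic carbon. Among the measured compounds shown here, the only measured step bears on this change indirectly: it exchanged one aryl group on the amide-type nitrogen for another and stayed within the scatter, so no step beyond the scatter is expected here either, and the estimated step of a 1.0-fold lower number from compound 2 to compound 3 (0.01 log units; within the scatter) is small. Compound 3 is expected to give 8000 nM, within 4000 nM to 16000 nM.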

Compound 3, half-maximal inhibitory concentration: 4100 nM
For compound 3 the middle estimate is 2.0-fold (0.29 log units) above the measured one; the measured number falls inside the stated range.
By their numbers in this assay, from the lowest: compounds 3, 2 and 1 (each within the scatter of the next, the first and the last beyond it).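

In this assay methoxy in place of hydrogen on the aromatic carbon ortho to a methoxy group gives a 2.0-fold lower number from compound 2 to compound 3 (0.30 log units; within the scatter) and so leaves the two compounds indistinguishable. Among the compounds shown here, the exchange of 2-methylphenyl for 3,4-dimethoxyphenyl on the amide-type nitrogen gives a 2.3-fold lower number from compound 1 to compound 3 (0.36 log units; beyond the scatter) as the first step beyond the scatter, though a modest one. Nothing available explains either step.

Still open, as far as these compounds go, is whether an amine or a carboxylic acid at this ring position would carry the number further. Also open, from the compounds shown here alone, is how a longer chain in the linker would read in this assay.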